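The compounds below may be only part of what the source reports. "The series", "measured", "known", "first", "only" and "open" are said of these compounds alone.

Working notes on the series. Compound 2 `CS(=O)(=O)c1ccc(-c2cc(C(=O)N[C@H]3CCCNC3)c(NC(N)=O)s2)cc1` and compound 3 `NC(=O)Nc1sc(-c2ccc(CN3CCCCC3)cc2)cc1C(N)=O` are the two members with a number in a functional assay on HT-29 cells (Homo sapiens); a lower number here means that less compound is needed, a higher number that more compound is needed for the effect. Compound 1 `NC(=O)Nc1sc(-c2ccccc2)cc1C(=O)NCC1CNCCO1` belongs to the same set, but in this assay compound 1 gives "not determined" (no result reported). In this assay compound 2 gives 200 nM, the lowest of the two numbers. In this assay compound 3 gives 270 nM, which lies within the scatter of the number for compound 2, so the two cannot be ordered against each other. Compound 4 `NC(=O)Nc1sc(-c2ccc(N)cc2)cc1C(=O)N[C@H]1CCCNC1` has not yet been measured. Against compound 2 it differs by amino in place of methylsulfonyl on an aromatic carbon. Among the measured compounds shown here, no measured pair in the set differs in this one place, so there is no recorded comparison from which to read the direction of this change in this assay. The step of a 1.6-fold higher number from compound 2 to compound 4 (0.20 log units; within the scatter) is expected to stay within the scatter, with a slight lean toward a higher number. Compound 4 is estimated in this assay at 320 nM, within a range from 80 nM to 1300 nM.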

Compound 4, half-maximal effective concentration: 920 nM
Compound 4: middle estimate off by 2.9-fold (0.46 log units), on the low side; low and high end bracket the measured number.
By their numbers in this assay, from the lowest: compounds 2 and 3 (each within the scatter of the next); then compound 4.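

Among the compounds shown here, the aromatic carbon para to a large group is the first place with a recorded one-place comparison, and the group there does register: amino in place of methylsulfonyl gives a 4.6-fold higher number from compound 2 to compound 4 (0.66 log units; beyond the scatter) in this assay. The direction is therefore now known for this one exchange, with methylsulfonyl the group that needs less compound for the effect, but a single pair defines no trend for this position. Nothing on hand explains the size or direction of this step.

On these data alone, whether a nitrile, a carboxylic acid or a methoxy group at this carbon would sit nearer compound 2 or compound 4 remains open. Also open, as far as these compounds go, is whether the step would keep its size with a different amide side chain on the shared core.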